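The compounds below may be only part of what the source reports. "The series", "measured", "known", "first", "only" and "open" are said of these compounds alone.

Working notes on the series, read-out a functional assay (Homo sapiens) for inhibition of Nucleic Acid, tested at 100 uM; on this read-out higher numbers stand for more inhibition at the one concentration tested (going by the name of the read-out) and lower numbers for less inhibition.

Three compounds carry a number. Compound 1, `Clc1[nH]ccc2ncnc1-2`, gives 6%. Compound 2, `CCNc1nccc2c1ncn2C1O[C@H](CO)[C@@H](O)[C@H]1O`, gives 4%. Compound 3, `OC[C@H]1O[C@@H](n2cnc3cnccc32)[C@H](O)[C@@H]1O`, has two entries rather than one number and gives 13%; 1% (2 entries); the spread between them is seen in the several entries of compound 3 in this assay, 13%; 1% (2 entries) and gives a sense of how far repeat runs of this assay can sit apart. Compound 2 and compound 1 lie within the scatter of each other, so no order between them is claimed, and all figures seen so far sit close to the bottom of the scale at the single concentration tested.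

Going by the values given here, no step between two measured compounds differing in one place exists in this set, so nothing is known yet about how a single change moves this read-out.

Compound 4, `CCCCCCNc1nccc2c1ncn2C1O[C@H](CO)[C@@H](O)[C@H]1O`, is not yet measured. It differs from compound 2 as follows: butyl in place of hydrogen on a saturated chain carbon, two bonds along the chain from a nitrogen on an aromatic ring. Among the compounds with values here, with no measured step of comparable kind to lean on, the expectation in this assay is no movement beyond the scatter, in either direction, and a value at the same low level as compound 2 and compound 1.

The estimate for compound 4 is therefore 8%, within 0% to 25%, which means an expected step of a number 4 percentage points higher from compound 2 to compound 4 (within the scatter).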

Compound 4, a percentage reported as inhibition, at one concentration (the size of the read-out at that concentration, not a potency): 8%
Compound 4: the middle estimate sits on the measured number at the digits printed; low and high end bracket the measured number.
By their numbers in this assay, from the lowest: compounds 2, 1 and 4 (each within the scatter of the next).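

Going by these compounds alone, this is the first single-place change that can be read: in this assay, going from ethylamino to hexylamino gives a number 4 percentage points higher from compound 2 to compound 4 (within the scatter). Adding butyl at this saturated chain carbon, two bonds along the chain from a nitrogen on an aromatic ring, therefore leaves the read-out at the same low level, with no change that can be told apart from the scatter. The step is also small beside the distance that repeat entries of a single compound can show, so it gives no direction for chain length at this position: the several entries of compound 3 in this assay, 13%; 1% (2 entries)

Still open, on these data alone, is whether anything placed on this chain can lift the read-out clear of the scatter, for instance a longer chain such as octyl, a terminal amine or carboxylic acid, or a phenyl ring in place of butyl. A single step also leaves open whether the response to chain length is flat throughout or changes at intermediate lengths such as propyl or butyl on the nitrogen.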